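Bromine-to-Hydrogen Swap on Two Bis-Chalcone Phenol Cores

The source may hold more compounds than are shown below. What is called first, only, known or untested is meant among the compounds shown, and "the series" means these compounds.

The study concerns four related compounds built on a phenol core carrying two enone arms and a pendant aryl ring. Compound 1 `Cc1cc(O)c(C(=O)/C=C/c2ccc(F)cc2)c(-c2ccc(Br)cc2)c1C(=O)/C=C/c1ccc(F)cc1` bears fluorine on both arms and a 4-bromophenyl pendant. Compound 3 `Cc1cc(O)c(C(=O)/C=C/c2ccc(Br)cc2)c(-c2ccc(Br)cc2)c1C(=O)/C=C/c1ccc(Br)cc1` bears bromine on both arms and the same 4-bromophenyl pendant, while compound 2 `Cc1cc(O)c(C(=O)/C=C/c2ccc(Br)cc2)c(-c2ccccc2)c1C(=O)/C=C/c1ccc(Br)cc1` keeps the brominated arms but carries a plain phenyl pendant. Compound 4 `Cc1cc(O)c(C(=O)/C=C/c2ccc(F)cc2)c(-c2ccccc2)c1C(=O)/C=C/c1ccc(F)cc1` pairs the fluorinated arms of compound 1 with the plain phenyl pendant of compound 2. The difference between the cores of compound 1 and compound 3 is not broken down here.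

In a functional assay on HeLa cells (Homo sapiens) for cytotoxicity, read by MTT assay, with a stated time of 24 h (a lower number here means a stronger inhibitor, a higher number a weaker inhibitor), compound 1 is reported as "not active" (no number reported). In this assay compound 3 gives 30000 nM, and compound 2 gives 33500 nM. The change between them, (hydrogen in place of bromo on an aromatic carbon), produced a 1.1-fold higher number from compound 3 to compound 2 (0.05 log units; within the scatter).

The change from compound 1 to compound 4 is the same change, (hydrogen in place of bromo on an aromatic carbon), made on the fluorinated core. Because the matched step a 1.1-fold higher number from compound 3 to compound 2 (0.05 log units; within the scatter) lies within the scatter, the step from compound 1 to compound 4 in this assay is expected to be small as well, and compound 1 itself has no number to anchor it, so compound 4 is expected to remain weak. For compound 4 in this assay the estimated value is 90000 nM, expected to lie between 30000 nM and 400000 nM.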

Compound 4, half-maximal inhibitory concentration: 30000 nM
The estimate for compound 4 lay 3.0-fold (0.48 log units) above the measured number; low and high end bracket the measured number.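

In this assay, among these compounds, compound 1 is reported as "not active" (no number reported) and gives no number, so no step from compound 1 to compound 4 can be read. The compounds shown leave open whether replacing bromo with hydrogen changes the reading on the fluorinated core, as no numerical comparison exists there. Nothing shown here offers an explanation for these readings.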